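Butoxy to ethoxy in the alkoxy series

The compounds below may be only part of what the source reports. "The series", "measured", "known", "first", "only" and "open" are said of these compounds alone.

Values in a functional assay on KB cells (Homo sapiens) for antiproliferative activity, read by sulforhodamine B assay, with a stated time of 3 days; a lower number here means that less compound is needed, a higher number that more compound is needed for the effect:
Compound 1 `CCCC1=C(OC)C(CCC)(CCC)C(=O)/C(=C(O)\C=C\c2ccccc2)C1=O`: 4.6 uM
Compound 2 `CCCC1=C(OCCC(C)C)C(CCC)(CCC)C(=O)/C(=C(O)\C=C\c2ccccc2)C1=O`: 10.6 uM
Compound 3 `CCCCOC1=C(CCC)C(=O)/C(=C(O)/C=C/c2ccccc2)C(=O)C1(CCC)CCC`: 8 uM

Compound 3 stands within the scatter of both other compounds, with a 1.7-fold higher number from compound 1 to compound 3 (0.24 log units; within the scatter) and a 1.3-fold lower number from compound 2 to compound 3 (0.12 log units; within the scatter). Compound 4 `CCCC1=C(OCC)C(CCC)(CCC)C(=O)/C(=C(O)\C=C\c2ccccc2)C1=O` turns butoxy into ethoxy: hydrogen in place of ethyl on a saturated chain carbon, two bonds along the chain from an oxygen on an unsaturated carbon. This places hydrogen in place of ethyl on a saturated chain carbon, two bonds along the chain from an oxygen on an unsaturated carbon. The closest measured change is a 1.7-fold higher number from compound 1 to compound 3 (0.24 log units; within the scatter), and only a 2.3-fold higher number from compound 1 to compound 2 (0.36 log units; beyond the scatter) clears the scatter. A small move towards compound 1 is therefore expected in this assay, with a 1.3-fold lower number from compound 3 to compound 4 (0.12 log units; within the scatter) as the expected step, not beyond the scatter. For compound 4 the estimated value is 6 uM, within an expected range of 3.5 uM to 10 uM.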

Compound 4, concentration for half-maximal effect: 6.4 uM
Estimate against measurement, compound 4: 1.1-fold (0.03 log units) below; measured number inside the range.
By their numbers in this assay, from the lowest: compounds 1, 4, 3 and 2 (each within the scatter of the next, the first and the last beyond it).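

In this assay the ethoxy compound 4 lies within the scatter of all three other alkoxy compounds: a 1.3-fold lower number from compound 3 to compound 4 (0.10 log units; within the scatter), a 1.7-fold lower number from compound 2 to compound 4 (0.22 log units; within the scatter) and a 1.4-fold higher number from compound 1 to compound 4 (0.14 log units; within the scatter). Butoxy to ethoxy therefore does not clear the scatter at this position, and only the step joining compound 1 and compound 2 remains beyond it. Hydrogen in place of methyl on the alkoxy chain also reads alike in two settings: the same change on two cores in this assay, a 1.3-fold lower number (0.12 log units; within the scatter) from compound 2 to compound 3 and a 1.4-fold lower number (0.14 log units; within the scatter) from compound 4 to compound 1, 1.1-fold (0.02 log units) apart, within the scatter of two such steps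

Still open, going by these compounds, is whether an amine or a carboxylic acid at the end of this chain, or a longer chain, would move the number beyond the scatter of compound 4.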